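The source may hold more compounds than are shown below. What is called first, only, known or untested is meant among the compounds shown, and "the series" means these compounds.

Compound 1 `Cc1ccc(NC(=O)c2c(O)c3cccnc3n(-c3ccccc3)c2=O)cc1` was tested in a functional assay on the whole organism for inhibition, with Rattus norvegicus as the target, read by cytopathic effect and paw edema, at a dose of 100 mg/kg by the oral route (on this read-out lower numbers stand for less inhibition and higher numbers for more inhibition at the one dose given (going by the name of the read-out)), where compound 1 gives 2.2%. Among the measured compounds shown here, only one other compound has been measured: compound 2 `Nc1ccc(NC(=O)c2c(O)c3cccnc3n(-c3ccccc3)c2=O)cc1` gives 0% in this assay. The step of a number 2.2 percentage points lower from compound 1 to compound 2 (within the scatter) shows that the two numbers cannot be told apart. The unmeasured compound 3 `O=C(Nc1ccncc1)c1c(O)c2cccnc2n(-c2ccccc2)c1=O` differs from compound 1 by pyridin-4-yl in place of 4-methylphenyl on an amide-type nitrogen. For the measured compounds named here, the single measured step, a number 2.2 percentage points lower from compound 1 to compound 2 (within the scatter), also reshapes the 4-methylphenyl group and produced nothing beyond the scatter, yet it does not replace one ring with another, so it bears only loosely on the present change. With both measured compounds close to zero, the expected step of a number 0.2 percentage points lower from compound 1 to compound 3 (within the scatter) is nothing beyond the scatter. Compound 3 is therefore estimated at 2%, within a range from 0% to 12%.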

Compound 3, a percentage reported as inhibition, in the whole organism at one dose (the size of the read-out at that dose, not a potency): 24.3%
Beside the measured number, compound 3's estimate is 22.3 percentage points below it, and the stated range ends below it.
By their numbers in this assay, from the lowest: compounds 2 and 1 (each within the scatter of the next); then compound 3.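

In this assay, the group on the amide-type nitrogen does move the number: pyridin-4-yl in place of 4-methylphenyl gives a number 22.1 percentage points higher from compound 1 to compound 3 (beyond the scatter), and pyridin-4-yl in place of 4-aminophenyl gives a number 24.3 percentage points higher from compound 2 to compound 3 (beyond the scatter). Among the compounds shown here, the earlier swap of methyl for amino stayed within the scatter, which makes this the first change at this position to go beyond it. Here the whole ring is exchanged: a ring nitrogen enters while the methyl or amino group leaves. Nothing measured here bears on why the number rises.

The compounds shown cannot separate the arrival of the ring nitrogen from the loss of the group on the ring; plain phenyl on the amide-type nitrogen would speak to that. Pyridin-3-yl and pyridin-2-yl would show whether the place of the ring nitrogen counts.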